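The source may report more compounds than this note shows. Statements on the series, on what has been measured and on what is new or still open speak of the compounds shown alone.

Measured in a functional assay on MCF7 cells (Homo sapiens) for cytotoxicity, read by MTT assay, with a stated time of 4 h; a higher number here means a weaker inhibitor, a lower number a stronger inhibitor:
- Compound 1 `COC(=O)C1=CO[C@@H](O[C@@H]2O[C@H](COC(c3ccccc3)(c3ccccc3)c3ccccc3)[C@@H](O)[C@H](O)[C@H]2O)[C@@H]2[C@@H](C)[C@@H](O)C[C@H]12`: 1 ug/mL
- Compound 2 `COC(=O)C1=CO[C@@H](O[C@@H]2O[C@H](CO)[C@@H](OC(C)=O)[C@H](OC(C)=O)[C@H]2OC(C)=O)[C@@H]2[C@@H](C)[C@@H](OC(C)=O)C[C@H]12`: "not active" (no number reported)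

Compound 2 has no place on the number scale: compound 2 was reported only as "not active" (no number reported), with no single value. The next structure is compound 3 `COC(=O)C1=CO[C@@H](O[C@@H]2O[C@H](COC(=O)c3cccc([N+](=O)[O-])c3)[C@@H](OC(C)=O)[C@H](OC(C)=O)[C@H]2OC(C)=O)[C@@H]2[C@@H](C)[C@@H](OC(C)=O)C[C@H]12`. The change (3-nitrophenyl)carbonyl in place of hydrogen on an oxygen on a saturated carbon puts (3-nitrophenyl)carbonyl in place of hydrogen on an oxygen on a saturated carbon, and the rest of the structure stays the same. Without a number at the starting point, the size of this step in this assay cannot be counted. The expected direction is towards a stronger inhibitor, with a measurable but modest value, weaker than compound 1 at 1 ug/mL. Another report without a number remains quite possible. For compound 3 the estimated value is 10 ug/mL, with an expected range of 1.5 ug/mL to 60 ug/mL.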

Compound 3, half-maximal inhibitory concentration: 1.25 ug/mL
Beside the measured number, compound 3's estimate is 8.0-fold (0.90 log units) above it; measured number below the stated range.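

No step can be read from compound 2 to compound 3: compound 2 carries only the report "not active", without a number. The compounds shown leave open how much the (3-nitrophenyl)carbonyl group alone changes activity. No measurement here explains the result of compound 3.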